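The compounds below may be only part of what the source reports. "The series", "measured", "known", "first", "only" and "open" are said of these compounds alone.

Series notes. Compound 1 `CCOC(=O)c1c(O)c2cccnc2n(-c2ccccc2)c1=O` gives 23.5% in a functional assay on the whole organism for inhibition, with Rattus norvegicus as the target, read by paw edema, at a dose of 100 mg/kg by the oral route; a lower number here means less inhibition, a higher number more inhibition at the dose given (going by the name of the read-out). Compound 2 `CN(C)CCNC(=O)c1c(O)c2cccnc2n(-c2ccccc2)c1=O` gives 22.6%, the step being a number 0.9 percentage points lower from compound 1 to compound 2 (within the scatter). Compound 3 `Cc1ccc(NC(=O)c2c(O)c3cccnc3n(-c3ccccc3)c2=O)cc1` gives -3.5%, the lowest of the three numbers, with a number 27 percentage points lower from compound 1 to compound 3 (beyond the scatter) and a number 26.1 percentage points lower from compound 2 to compound 3 (beyond the scatter).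

Compound 4 `O=C(Nc1cccc([N+](=O)[O-])c1)c1c(O)c2cccnc2n(-c2ccccc2)c1=O` is still unmeasured; it differs from compound 3 by 3-nitrophenyl in place of 4-methylphenyl on an amide-type nitrogen. Among the compounds with values here, no measured step exchanges one aryl group for another on the amide-type nitrogen. Within the data shown here, the only step at that position, a number 26.1 percentage points lower from compound 2 to compound 3 (beyond the scatter), replaces an alkyl chain by an aryl group and so says little about the size of an aryl-to-aryl exchange. For compound 4 the expected step is a number 5.5 percentage points higher from compound 3 to compound 4 (within the scatter), within the scatter. Compound 4 is estimated at 2%, range -15% to 20%.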

Compound 4, a percentage reported as inhibition, in the whole organism at one dose (the size of the read-out at that dose, not a potency): 5.7%
Compound 4: the middle estimate sits 3.7 percentage points below what was measured; low and high end bracket the measured number.
By their numbers in this assay, from the lowest: compounds 3 and 4 (each within the scatter of the next); then compounds 2 and 1 (each within the scatter of the next).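

The exchange of one aryl group for another on the amide-type nitrogen gives a number 9.2 percentage points higher from compound 3 to compound 4 (within the scatter) in this assay and so does not separate 3-nitrophenyl from 4-methylphenyl. The gap to the compounds without an aryl amide also holds for this second aryl group, with a number 16.9 percentage points lower from compound 2 to compound 4 (beyond the scatter) for the exchange from 2-(dimethylamino)ethyl and a number 17.8 percentage points lower from compound 1 to compound 4 (beyond the scatter) for the exchange from ethoxy. No evidence on the reason for these numbers is at hand.

Open, as far as these compounds go, is whether a phenyl ring carrying an amine or a carboxylic acid, or a longer chain between the amide-type nitrogen and the phenyl ring, would stay with compound 3 and compound 4 or move toward compound 1 and compound 2.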